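Furan-2-yl in place of pyrazin-2-yl on the shared core

The source may report more compounds than this note shows. Statements on the series, on what has been measured and on what is new or still open speak of the compounds shown alone.

Going by the values given here, compound 3 `c1ccc(-c2cnccn2)c(OCC2=NCCN2)c1` is the one member of the series with a number in a functional assay for activation of Alpha-1B adrenergic receptor (Homo sapiens), read by calcium flux (on this read-out lower numbers stand for an effect already at smaller amounts and higher numbers for an effect only at larger amounts of compound), where compound 3 gives 631 nM. Compound 1 `c1ccc(-c2ccncc2)c(OCC2=NCCN2)c1` reaches only the limit < 100000 nM in this assay. Compound 2 `Cc1ccnc(-c2ccccc2OCC2=NCCN2)c1` likewise reaches only the limit < 100000 nM. The step that the limit leaves unreadable from compound 1 to compound 3 thus has no readable size, as the limit of < 100000 nM in this assay, at which 2 of the 3 values shown sit, shows. Compound 4 `c1coc(-c2ccccc2OCC2=NCCN2)c1` differs from compound 3 by furan-2-yl in place of pyrazin-2-yl on an aromatic carbon. No measured step bears on this change: the single step shown is unreadable, and compound 2 has no one-place difference to compound 3 or compound 4. The step of a 1.6-fold higher number from compound 3 to compound 4 (0.20 log units; within the scatter) is therefore expected to stay within the usual scatter, with wide uncertainty. Compound 4 is expected at 1000 nM, from 150 nM to 20000 nM.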

Compound 4, half-maximal effective concentration: 10 nM
Estimate against measurement, compound 4: 100-fold (2.00 log units) above; measured number below the stated range.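

In this assay, going by these compounds alone, furan-2-yl in place of pyrazin-2-yl gives a 63-fold lower number from compound 3 to compound 4 (1.80 log units; beyond the scatter) and is the first readable measure of a change on this aromatic carbon, so the ring held there can strongly shift the read-out. The steps from compound 1 to compound 3 and to compound 4 cannot be read: the limit of < 100000 nM in this assay, at which 2 of the 4 values shown sit. Nothing shown gives a cause for the step from pyrazin-2-yl to furan-2-yl.

The compounds shown leave open whether the lower number follows the ring oxygen or the five-membered ring. Thiophen-2-yl, pyrrol-2-yl or phenyl on the same carbon would bear on that question.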